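The source may report more compounds than this note shows. Statements on the series, on what has been measured and on what is new or still open speak of the compounds shown alone.

In a physicochemical assay for solubility, measured as kinetic solubility (a higher number here means a more soluble compound, a lower number a less soluble compound), compound 1 `Oc1c(-c2nnc(Cc3ccc(Cl)cc3)[nH]2)ncc2cccnc12` gives 219000 nM. For compound 2 `Oc1c(-c2nc(C(O)c3ccccc3)n[nH]2)ncc2cccnc12` the reading is a limit of the assay and not a number: > 250000 nM. Compound 2 thus stands on (the limit of > 250000 nM in this assay, at which 1 of the 2 values shown sits). Compound 3 `Cc1n[nH]c(-c2ncc3cccnc3c2O)n1` shares the core of compound 2 but carries methyl in place of hydroxy(phenyl)methyl on an aromatic carbon of the five-membered aromatic ring with 3 nitrogen (methyl in place of hydroxy(phenyl)methyl on an aromatic carbon). The expected step of an at least 1.1-fold lower number from compound 2 to compound 3 (0.05 log units; that floor lies within the scatter) is none beyond the usual scatter in this assay, in either direction. Compound 3 is estimated at 220000 nM, with an expected range from 110000 nM to 250000 nM.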

Compound 3, solubility: > 250000 nM
Compound 3 gave a limit, no number; the forecaster's own chance of this, stated with the estimate: 45%; middle value at least 1.1-fold (0.05 log units) away from the limit.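

Compound 2 and compound 3 both give a limit of the assay and not a number in this assay, so no step can be read between them: the limit of > 250000 nM in this assay, at which 2 of the 3 values shown sit.

The compounds shown leave open whether methyl in place of hydroxy(phenyl)methyl on an aromatic carbon shifts the reading at all.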